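Halogen swap on the shared core in a glioma cell assay

The source may hold more compounds than are shown below. What is called first, only, known or untested is meant among the compounds shown, and "the series" means these compounds.

Measured compounds:
- compound 1, `O=C(CSc1nnnn1-c1ccccc1)N/N=c1/scc(-c2ccc(Br)cc2)n1-c1ccccc1`: 21 ug/mL
- compound 2, `Cn1nnnc1SCC(=O)N/N=c1/scc(-c2ccc(Br)cc2)n1-c1ccccc1`: "not determined" (no result reported)

For the measured compounds named here, compound 1 is the only compound here with a number. In a functional assay on C6 cells (Rattus norvegicus) for cytotoxicity, read by MTT assay, with a stated time of 24 h (a higher number here means a weaker inhibitor, a lower number a stronger inhibitor), compound 1 gives 21 ug/mL. Compound 2, `Cn1nnnc1SCC(=O)N/N=c1/scc(-c2ccc(Br)cc2)n1-c1ccccc1`, carries a methyl on the tetrazole in place of the phenyl of compound 1; for compound 2 the outcome of this assay is "not determined" (no result reported), so no comparison between the two is possible. Compound 1 therefore stands alone as the reference point.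

Compound 3, `O=C(CSc1nnnn1-c1ccccc1)N/N=c1/scc(-c2ccc(F)cc2)n1-c1ccccc1`, differs from compound 1 in one place: fluoro in place of bromo on an aromatic carbon. Going by the values given here, with no measured pair to learn from, the expected step in this assay from compound 1 to compound 3 is small, a 1.3-fold higher number from compound 1 to compound 3 (0.12 log units; within the scatter), and is estimated to sit within the usual scatter, with a slight lean toward a weaker result. Compound 3 is estimated at 28 ug/mL in this assay, expected to fall between 12 ug/mL and 65 ug/mL.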

Compound 3, half-maximal inhibitory concentration: 24.3 ug/mL
For compound 3 the middle estimate is 1.2-fold (0.06 log units) above the measured one, and the stated range covers the measured number.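

In this assay the change from bromo to fluoro, on an aromatic carbon para to a large group, gives a 1.2-fold higher number from compound 1 to compound 3 (0.06 log units; within the scatter). For the compounds shown here, this is the first measured step on the shared core, and it shows that these two halogens cannot be told apart at this position in this assay. No measurement shown here bears on the reason for this result.

The compounds shown leave open whether a group of another kind at this same position, such as an amine, a carboxylic acid or a longer alkyl chain, would move the number beyond the scatter. They also leave open whether replacing the phenyl on the tetrazole with another group, such as a benzyl, would change the reading in this assay.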